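The source may report more compounds than this note shows. Statements on the series, on what has been measured and on what is new or still open speak of the compounds shown alone.

Going by the values given here, in a functional assay on PC-3 cells (Homo sapiens) for inhibition, read by MTT assay (on this read-out higher numbers stand for weaker inhibition of growth and lower numbers for stronger inhibition of growth), compound 1 `CC1=C(/C=C/C(C)=C/C=C/C(C)=C\C(=O)Nc2ccc(O)cc2)C(C)(C)CCC1n1ccnc1` gives 11700 nM, the middle of the three numbers so far. Compound 2 `CC1=C(/C=C/C(C)=C/C=C/C(C)=C\C(=O)Nc2ccc(F)cc2)C(C)(C)CCC1n1ccnc1` gives 30200 nM, and compound 3 `CC1=C(/C=C/C(C)=C/C=C/C(C)=C\C(=O)NCc2ccc(O)cc2)C(C)(C)CCC1n1ccnc1` gives 3540 nM.

Compound 4 `CC1=C(/C=C/C(C)=C/C=C/C(C)=C\C(=O)NCc2ccccc2)C(C)(C)CCC1n1ccnc1` has not yet been measured. It differs from compound 1 by benzyl in place of 4-hydroxyphenyl on an amide-type nitrogen.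

Among the compounds with values here, two measured steps bear on this change. The closer one is a 3.3-fold lower number from compound 1 to compound 3 (0.52 log units; beyond the scatter), a modest step beyond the scatter, with 4-hydroxybenzyl in place of 4-hydroxyphenyl on the same nitrogen. Compound 4 keeps the benzyl of compound 3 but has no hydroxy. The second is a 2.6-fold higher number from compound 1 to compound 2 (0.41 log units; beyond the scatter), also modest and beyond the scatter, with fluoro in place of hydroxy on an aromatic carbon. It runs in the opposite direction, though it replaces the hydroxy rather than simply removing it. Within the data shown here, no measured pair shows a plain removal of the hydroxy, so that part of the change remains open.

Among the measured compounds shown here, a small step towards a lower number is therefore expected in this assay, smaller than the one seen for compound 3. The expected change is a 2.1-fold lower number from compound 1 to compound 4 (0.33 log units; beyond the scatter). Compound 4 is estimated at 5500 nM, with an expected range of 2200 nM to 14000 nM.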

Compound 4, concentration for 50% growth inhibition: > 100000 nM
Compound 4: a limit, no number (the forecaster's own chance of this, stated with the estimate: 3%); at least 18-fold (1.25 log units) between middle value and limit.
By their numbers in this assay, from the lowest: compound 3; then compound 1; then compound 2. At a limit, above all of these: compound 4.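

In this assay compound 4 stands at a limit, not at a number: the limit of > 100000 nM in this assay, at which 1 of the 4 values shown sits.

Going by these compounds alone, on the benzyl amide, the hydroxy matters far more than the earlier compounds suggested: an at least 28-fold higher number from compound 3 to compound 4 (1.45 log units; beyond the scatter), a large step for the loss of the hydroxy from the benzyl group, whereas the steps among compounds 1, 2 and 3 were all modest. Benzyl in place of the aryl group therefore does not by itself bring the lower number seen for compound 3, since the change runs upward in both comparisons, with an at least 8.5-fold higher number from compound 1 to compound 4 (0.93 log units; beyond the scatter) and an at least 3.3-fold higher number from compound 2 to compound 4 (0.51 log units; beyond the scatter), so within these compounds the low number of compound 3 goes with benzyl and hydroxy together.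

From the compounds shown here alone, all three steps to compound 4 are bounds, so their true sizes remain unknown. Still open, going by these compounds, is whether the hydroxy itself is needed on the benzyl group or whether a methoxy, an amine or a carboxylic acid could stand in its place, and how a plain phenyl or a longer chain on the amide nitrogen would read.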